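Swapping the benzyl ether for a cyclopentyl ether

The source may hold more compounds than are shown below. What is called first, only, known or untested is meant among the compounds shown, and "the series" means these compounds.

Measured so far:
compound 1 `CCc1cc(C(C)=O)c(OC)cc1OCCCCCC(C)(C)c1nnn[nH]1`, 5500 nM
compound 2 `CCc1cc(C(C)=O)c(OCc2cccc(C)c2)cc1OCCCCCC(C)(C)c1nnn[nH]1`, 1200 nM

In an assay on isolated protein for antagonist activity at Bile acid receptor (Homo sapiens), read by HTRF, with a stated time of 30 min (on this read-out higher numbers stand for weaker inhibition and lower numbers for stronger inhibition), compound 2 gives the lowest of the two numbers; its nearest neighbour is compound 1, and the step of a 4.6-fold lower number from compound 1 to compound 2 (0.66 log units; beyond the scatter) lies beyond the scatter. Compound 3 `CCc1cc(C(C)=O)c(OC2CCCC2)cc1OCCCCCC(C)(C)c1nnn[nH]1` differs from compound 2 by cyclopentyl in place of 3-methylbenzyl on an oxygen on an aromatic ring. Among the measured compounds shown here, only that one step bears on it, and it ran the other way, so a modest rise toward compound 1 is expected, within the span of the two measured values. Compound 3 is therefore estimated at 2500 nM (range 1000 nM to 6500 nM), a step of a 2.1-fold higher number from compound 2 to compound 3 (0.32 log units; beyond the scatter).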

Compound 3, half-maximal inhibitory concentration: 3300 nM
Estimate against measurement, compound 3: 1.3-fold (0.12 log units) below; the range from low to high includes it.
By their numbers in this assay, from the lowest: compound 2; then compounds 3 and 1 (each within the scatter of the next).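

In this assay, cyclopentyl on the oxygen on the aromatic ring does not keep the value reached with 3-methylbenzyl (a 2.8-fold higher number from compound 2 to compound 3 (0.44 log units; beyond the scatter)). Set against methyl at the same place (a 1.7-fold lower number from compound 1 to compound 3 (0.22 log units; within the scatter)), cyclopentyl cannot be told apart, so at this position a five-membered non-aromatic ring of carbon does not match the 3-methylbenzyl result. No available evidence explains this difference.

The compounds shown leave open whether an unsubstituted benzyl group would match compound 2, and so what the methyl on that ring contributes. They also leave open how a pyridylmethyl group would compare at this oxygen.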